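The source may hold more compounds than are shown below. What is called first, only, known or untested is meant among the compounds shown, and "the series" means these compounds.

Measured compounds:

Compound 1, `CCOC(=O)[C@@H]1CCCN(S(=O)(=O)c2ccc(S(=O)(=O)N(CC)C(C)C)cc2)C1`: 1000 nM
Compound 2, `CC(C)c1noc(C2CCN(C(=O)[C@@H]3CCCN(S(=O)(=O)c4ccc(S(=O)(=O)C(C)C)cc4)C3)CC2)n1`: 50 nM
Compound 3, `CCN(CC)C(=O)c1ccc(S(=O)(=O)N2CCC[C@@H](C(=O)N3CCN(c4nc(C(C)C)no4)CC3)C2)cc1`: 100 nM

All three were tested in a functional assay on MIA PaCa-2 cells (Homo sapiens) for inhibition, read by MTT assay, with a stated time of 7 days; a higher number here means a weaker inhibitor, a lower number a stronger inhibitor. Compound 1 shows the highest number of the three, making it the weakest inhibitor in this set; compound 3 comes closest to it and compound 2 lies furthest from it, and both gaps are beyond the scatter. Compound 2 and compound 3 differ from compound 1 in several places at once, so neither tells what a single exchange on the sulfonyl sulfur would do.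

Compound 4, `CCOC(=O)[C@@H]1CCCN(S(=O)(=O)c2ccc(S(=O)(=O)N3CCNCC3)cc2)C1`, has not yet been measured. It differs from compound 1 in one place: piperazin-1-yl in place of ethyl(isopropyl)amino on a sulfonyl sulfur. Put another way, the ethyl(isopropyl)sulfamoyl becomes a (piperazin-1-yl)sulfonyl. For the measured compounds named here, no measured pair shows this exchange, so there is nothing to lean on beyond compound 1 itself. In this assay the expected step is a 2.0-fold higher number from compound 1 to compound 4 (0.30 log units; within the scatter), a modest move toward a weaker inhibitor that may not clear the scatter. Compound 4 is therefore estimated at 2000 nM, in a range from 500 nM to 10000 nM.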

Compound 4, half-maximal inhibitory concentration: > 30000 nM
Compound 4 gave a limit, no number (the forecaster's own chance of this, stated with the estimate: 20%); at least 15-fold (1.17 log units) between middle value and limit.
By their numbers in this assay, from the lowest: compounds 2 and 3 (each within the scatter of the next); then compound 1. At a limit, above all of these: compound 4.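

In this assay, the sulfonyl sulfur proves to be a sensitive place on the shared core: exchanging ethyl(isopropyl)amino for piperazin-1-yl gives an at least 30-fold higher number from compound 1 to compound 4 (1.47 log units; beyond the scatter). The value of compound 4 is a limit of the assay, not a number: the limit of > 30000 nM in this assay, at which 1 of the 4 values shown sits.

Both groups have the same number of heavy atoms, so this position does not accept every group of that count; piperazin-1-yl brings a six-membered ring, a hydrogen-bond donor and a hydrogen-bond acceptor, all absent from ethyl(isopropyl)amino.

The compounds shown do not separate the effect of the ring from that of its second nitrogen. Piperidin-1-yl, a six-membered ring with only one nitrogen, on the same sulfonyl sulfur would address that question.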